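Chain substituent series: carboxy variant of compound 3

This account rests on a few compounds, and the source may have more. Where it says the series, first, only, none or still open, it means among the compounds named here.

Compound 1 `CCOC(CCn1c(Cc2nn(C)c(=O)c3ccccc23)nnc1SCCCCCCCC(=O)Nc1ccc(Cl)cc1Cl)OCC` — 12100 nM
Compound 2 `Cn1nc(Cc2nnc(SCCCCCCCC(=O)Nc3ccc(Cl)cc3Cl)n2CCC=O)c2ccccc2c1=O` — 2500 nM
Compound 3 `CN(C)CCCn1c(Cc2nn(C)c(=O)c3ccccc23)nnc1SCCCCCCCC(=O)Nc1ccc(Cl)cc1Cl` — 3700 nM

All three measured compounds share one core and differ only in the group on the saturated chain carbon two bonds along the chain from an aromatic nitrogen. In an assay on 32D cells for inhibition of interleukin-15 (Mus musculus), read by resazurin assay, with stated times of 30 min and 2.5 days, in the presence of a further agent that is not named here (on this read-out higher numbers stand for weaker inhibition and lower numbers for stronger inhibition), compound 3 stands second highest of the three numbers; its nearest neighbour is compound 2, from which it is separated by a 1.5-fold higher number from compound 2 to compound 3 (0.17 log units; within the scatter), while compound 1 lies furthest away, with a 3.3-fold lower number from compound 1 to compound 3 (0.51 log units; beyond the scatter). The other step at this position, a 4.8-fold lower number from compound 1 to compound 2 (0.68 log units; beyond the scatter), points the same way as the step from compound 1 to compound 3: moving away from diethoxymethyl lowers the number modestly, whereas formyl and (dimethylamino)methyl are not distinguishable from each other.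

Compound 4 `Cn1nc(Cc2nnc(SCCCCCCCC(=O)Nc3ccc(Cl)cc3Cl)n2CCC(=O)O)c2ccccc2c1=O` carries carboxy in place of (dimethylamino)methyl on a saturated chain carbon, two bonds along the chain from an aromatic nitrogen. For the measured compounds named here, no measured step exchanges a carboxy at this position, so the expectation rests on the observation that the two smaller groups already tested sit close together in this assay. A step in this assay of no more than modest size, in no firm direction, is therefore expected; the estimate is a 1.2-fold lower number from compound 3 to compound 4 (0.09 log units; within the scatter). Compound 4 is expected to give about 3000 nM in this assay, within 1200 nM to 8000 nM.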

Compound 4, half-maximal inhibitory concentration: 23500 nM
Estimate against measurement, compound 4: 7.8-fold (0.89 log units) below; measured number above the stated range.
By their numbers in this assay, from the lowest: compounds 2 and 3 (each within the scatter of the next); then compounds 1 and 4 (each within the scatter of the next).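

Carboxy at this position, on a saturated chain carbon, two bonds along the chain from an aromatic nitrogen, breaks the closeness seen so far: in this assay the change gives a 6.4-fold higher number from compound 3 to compound 4 (0.80 log units; beyond the scatter) and also a 9.4-fold higher number from compound 2 to compound 4 (0.97 log units; beyond the scatter) as the exchange of hydrogen for hydroxy on a carbonyl carbon. The position therefore separates groups more sharply than formyl and (dimethylamino)methyl alone suggested, and with a 1.9-fold higher number from compound 1 to compound 4 (0.29 log units; within the scatter) as the remaining step, carboxy and diethoxymethyl are not distinguished, so the four compounds form a pair with lower numbers, compound 2 and compound 3, and a pair with higher numbers, compound 1 and compound 4. No measurement here bears on the reason for this separation.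

From the compounds shown here alone, it remains open whether a methyl ester or a primary amide at this place would stay with compound 2 and compound 3 or join compound 1 and compound 4. Going by these compounds, it is equally open whether a longer chain ending in a carboxylic acid, or a plain propyl group without any terminal function, would change the picture.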